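Removing the benzamido group from compound 1

The source may report more compounds than this note shows. Statements on the series, on what has been measured and on what is new or still open speak of the compounds shown alone.

In an ADME assay on A549 cells (Homo sapiens) for cytotoxicity, read by MTT assay, with a stated time of 4 days (a higher number here means a weaker inhibitor, a lower number a stronger inhibitor), compound 1 (`COc1cc(C[C@H]2C(=O)OC[C@@H]2Cc2ccc(OC)c(OC)c2)ccc1NC(=O)c1ccccc1`) gives > 50000 nM as a limit and not a number. Compound 2 (`COc1cc(C[C@H]2C(=O)OC[C@@H]2Cc2ccc(OC)c(OC)c2)ccc1Nc1ccc(F)cc1`) gives > 50000 nM as a limit too. Compound 3 (`COc1cc(C[C@H]2C(=O)OC[C@@H]2Cc2ccc(OC)c(OC)c2)ccc1NCc1ccccc1`) likewise gives > 50000 nM as a limit. The readings shown therefore come down to one: the limit of > 50000 nM in this assay, at which 3 of the 3 values shown sit, and no measured number.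

Compound 4 (`COc1cccc(C[C@H]2C(=O)OC[C@@H]2Cc2ccc(OC)c(OC)c2)c1`) keeps the core of compound 1 and gives up the whole benzamido group, with hydrogen in its place on an aromatic carbon (hydrogen in place of benzamido on an aromatic carbon).

For the measured compounds named here, three measured steps bear on this change, each exchanging one group for another on the same nitrogen: a step that the two limits leave unreadable from compound 1 to compound 2 and a step that the two limits leave unreadable from compound 1 to compound 3 and a step that the two limits leave unreadable from compound 2 to compound 3 make up the set. None of them removes the nitrogen group, so the size of the present step cannot be taken from them. Going by the values given here, with the limit of > 50000 nM in this assay, at which 3 of the 3 values shown sit, as the only guide, no step beyond the scatter is expected in this assay in either direction, and a further limit is the likeliest result. The estimated step is a number no higher from compound 1 to compound 4 (the limit leaves the size open) and carries little weight. For compound 4 the estimate is 50000 nM with an expected range of 25000 nM to 100000 nM as a rough guide.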

Compound 4, half-maximal inhibitory concentration: > 50000 nM
Compound 4 was reported as a limit; the forecaster's own chance of this, stated with the estimate: 85%; the middle value sits exactly at the limit.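

In this assay compound 4 gives > 50000 nM, a limit and not a number. The steps to compound 4 from compound 1, compound 2 and compound 3 join limits only, so none can be read. The compounds shown leave open what number any of the four would give, and whether any group at this place would bring a measured value in this assay.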